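The source may report more compounds than this note shows. Statements on the series, on what has been measured and on what is new or still open speak of the compounds shown alone.

Measured so far:
compound 1 `CCCCCCOC(=O)NC(=O)Oc1c(C(C)C)cccc1C(C)C`: 53 nM
compound 2 `CCCCCCCCCCCCCCOC(=O)NC(=O)Oc1c(C(C)C)cccc1C(C)C`: 10 nM
compound 3 `CCCCCCCC(C)OC(=O)NC(=O)Oc1c(C(C)C)cccc1C(C)C`: 97 nM

In an assay on microsomes from intestine for inhibition of acyl-CoA:cholesterol acyltransferase (Oryctolagus cuniculus) (a higher number here means a weaker inhibitor, a lower number a stronger inhibitor), compound 1 stands second highest of the three numbers. Its nearest neighbour is compound 3, reached by a 1.8-fold higher number from compound 1 to compound 3 (0.26 log units; within the scatter); its furthest is compound 2, reached by a 5.3-fold lower number from compound 1 to compound 2 (0.72 log units; beyond the scatter).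

Compound 4 `CC(C)c1cccc(C(C)C)c1OC(=O)NC(=O)SCc1ccco1` is not yet measured. It differs from compound 1 by ((furan-2-yl)methyl)sulfanyl in place of hexyloxy on a carbonyl carbon. Both measured steps change only what sits on the oxygen beside the carbonyl, and neither exchanges that oxygen for sulfur or brings in a ring, so they bear on this step only loosely; the nearer one, the step from compound 1 to compound 3, lay within the scatter, the other was modest. On this basis the expectation for this assay is a step of no clear direction, most likely within the scatter, with a wide range. Compound 4 is therefore estimated at 70 nM, between 20 nM and 250 nM. That estimate amounts to an expected step of a 1.3-fold higher number from compound 1 to compound 4 (0.12 log units; within the scatter).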

Compound 4, half-maximal inhibitory concentration: 470 nM
Compound 4: middle estimate off by 6.7-fold (0.83 log units), on the low side; measured number outside the range, above it.
By their numbers in this assay, from the lowest: compound 2; then compounds 1 and 3 (each within the scatter of the next); then compound 4.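

In this assay, ((furan-2-yl)methyl)sulfanyl in place of hexyloxy on the carbonyl carbon gives an 8.9-fold higher number from compound 1 to compound 4 (0.95 log units; beyond the scatter), the only listed step in the series that raises the number beyond the scatter. Matching the heavy-atom count of the leaving group therefore does not preserve the number at this position. No measurement bearing on the cause of this rise is available.

The step changes the linking atom and the chain together, so their contributions remain inseparable. Hexylsulfanyl or (furan-2-yl)methoxy at this position would divide the step.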